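A few compounds are considered here, and "the series" means these few. Any claim that something is new, unique, unknown or untested is made for them only; others in the source may bear on it.

Compound 1 `COc1cccc2ccc(CNCc3ccc(/C=C/C(=O)NO)cc3)nc12`: 750 nM
Compound 2 `COc1ccc2nc(CNCc3ccc(/C=C/C(=O)NO)cc3)ccc2c1`: 690 nM

In a functional assay on K562 cells (Homo sapiens) for antiproliferative activity, read by MTT assay, with a stated time of 48 h (on this read-out lower numbers stand for stronger inhibition and higher numbers for weaker inhibition), compound 2 gives 690 nM and compound 1 gives 750 nM, so the two values lie within the scatter of each other. Compound 3 `O=C(/C=C/c1ccc(CNCc2ccc3cc(Cl)ccc3n2)cc1)NO` keeps the core of compound 2 but has chloro in place of methoxy on an aromatic carbon. Within the data shown here, no measured pair shows what this change does. In this assay, the expected result is a 1.2-fold lower number from compound 2 to compound 3 (0.06 log units; within the scatter), a step with no firm direction and none beyond the scatter. Compound 3 is estimated at 600 nM, with an expected range of 250 nM to 1400 nM.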

Compound 3, half-maximal inhibitory concentration: 720 nM
The estimate for compound 3 lay 1.2-fold (0.08 log units) below the measured number; low and high end bracket the measured number.
By their numbers in this assay, from the lowest: compounds 2, 3 and 1 (each within the scatter of the next).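

In this assay, among these compounds, chloro in place of methoxy on this aromatic carbon gives a 1.0-fold higher number from compound 2 to compound 3 (0.02 log units; within the scatter) and provides the first direct comparison at this position. Within this single pair, the position accepts either group without a change beyond the scatter, even though chloro brings no hydrogen-bond acceptor and methoxy brings one. Nothing available accounts for this result.

The compounds shown leave open whether an amine or a carboxylic acid on this carbon would shift the number beyond the scatter. They also leave open what a longer chain, such as butoxy, would do there.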